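The source may hold more compounds than are shown below. What is called first, only, known or untested is meant among the compounds shown, and "the series" means these compounds.

Measured so far in a functional assay on MCF7 cells (Homo sapiens) for cytotoxicity, read by MTT assay, with a stated time of 72 h; on this read-out higher numbers stand for lower toxicity in this test and lower numbers for higher toxicity in this test:
Compound 1 `CSc1nc(NCCCCCO)c2ccccc2n1` gives > 100000 nM, which is a limit of the test and not a number.
Compound 2 `COc1ccc(CNc2nc(SC)nc3ccccc23)cc1` gives > 100000 nM, also a limit.
Compound 3 `Sc1nc(NCc2ccccc2)c2ccccc2n1` gives > 100000 nM, again a limit.

Compound 3 thus stands where every shown value stands: at the limit of > 100000 nM in this assay, at which 3 of the 3 values shown sit. Going by the values given here, no two measured compounds differ in a single place, so no measured step is available. Compound 4 `CSc1nc(NCc2ccccc2)c2ccccc2n1` is compound 3 changed at one place: methyl in place of hydrogen on a sulfur. Compound 1 and compound 2 also carry methyl on sulfur and sit at the limit of > 100000 nM in this assay, at which 3 of the 3 values shown sit, so the expected step from compound 3 to compound 4 in this assay is none beyond the usual scatter. That expected step is a step that the limit leaves unreadable from compound 3 to compound 4. Compound 4 is therefore estimated at 150000 nM, within a range from 50000 nM to 500000 nM, and is expected to be reported as a limit once more.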

Compound 4, concentration lethal to 50% of the cells: > 100000 nM
Compound 4 ended at the assay's limit (the forecaster's own chance of this, stated with the estimate: 85%); the middle value is on the limit's open side.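

No step to compound 4 from compound 1, compound 2 or compound 3 can be read, because all four compounds share one limit: the limit of > 100000 nM in this assay, at which 4 of the 4 values shown sit.

The compounds shown leave open how far beyond that limit each one lies in this assay.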